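Configuration changes in a weak inhibitor series

The source may hold more compounds than are shown below. What is called first, only, known or untested is meant among the compounds shown, and "the series" means these compounds.

Compound 1 `O=C(/C=C/c1ccc(O)cc1)O[C@H]1[C@H](O[C@@H]2CCCC[C@H]2O)O[C@H](CO)[C@@H](O)[C@@H]1O` gives 20500 nM in a functional assay on BV-2 cells (Homo sapiens) for inhibition, with stated times of 30 min and 24 h; a lower number here means a stronger inhibitor, a higher number a weaker inhibitor.
Compound 2 `O=C(/C=C/c1ccc(O)cc1)O[C@H]1[C@H](O[C@H]2CCCC[C@@H]2O)O[C@H](CO)[C@@H](O)[C@@H]1O` gives 15500 nM in this assay.

Compound 2 holds the lowest of the two numbers, and its nearest neighbour is compound 1, with a 1.3-fold lower number from compound 1 to compound 2 (0.12 log units; within the scatter). Compound 3 `O=C(/C=C\c1ccc(O)cc1)O[C@@H]1[C@H](O[C@H]2CCCC[C@@H]2O)O[C@H](CO)[C@@H](O)[C@H]1O` is the next step: the two compounds have the same atoms and bonds and differ only in configuration as drawn: 3 of 8 stereo elements differ; a stereocentre at a saturated ring carbon is drawn R in compound 2 and S in compound 3; a stereocentre at a saturated ring carbon is drawn S in compound 2 and R in compound 3; a double bond is drawn E in compound 2 and Z in compound 3. Among the measured compounds shown here, the only measured step that bears on this is the one from compound 1 to compound 2, where the pair differ only in configuration as drawn the fact that compounds 1 and 2 differ only in the configuration as drawn and the step stayed within the scatter. Compound 3 is therefore expected to show no step beyond the scatter, no change at the digits printed from compound 2 to compound 3 (within the scatter). Compound 3 is estimated at 15500 nM, within 5000 nM to 50000 nM.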

Compound 3, half-maximal inhibitory concentration: 18100 nM
The estimate for compound 3 lay 1.2-fold (0.07 log units) below the measured number; the range from low to high includes it.
By their numbers in this assay, from the lowest: compounds 2, 3 and 1 (each within the scatter of the next).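

Compound 3 brings in what the first pair could not show: a double bond drawn Z rather than E, together with two other stereocentres, and this assay gives a 1.2-fold higher number from compound 2 to compound 3 (0.07 log units; within the scatter). With five of the eight stereo elements differing, it also gives a 1.1-fold lower number from compound 1 to compound 3 (0.05 log units; within the scatter). So far, even these larger differences in configuration stay within the scatter.

Going by these compounds, the effect of the double bond alone remains open, as it differs here only together with ring stereocentres. On these data alone, all three compounds share the same atoms, so whether adding an amine or a carboxylic acid would move the number beyond the scatter is also open.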